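A few compounds are considered here, and "the series" means these few. Any claim that something is new, unique, unknown or untested is made for them only; others in the source may bear on it.

In a functional assay on HT cells (Homo sapiens) for antiproliferative activity, read by fluorescence, with a stated time of 72 h (on this read-out lower numbers stand for stronger inhibition of growth and higher numbers for weaker inhibition of growth), three compounds built on one shared core have been measured so far. Compound 1 `CC(C)c1n[nH]c2c(NCc3ccc(-c4ccccn4)cc3)nc(SCC(N)=O)nc12` gives 192 nM, the second highest of the three numbers. Compound 2 `CC(C)c1n[nH]c2c(NCc3ccc(-c4ccccn4)cc3)nc(SCC3CNC(=O)O3)nc12` gives 80 nM, while compound 3 `CC(C)c1n[nH]c2c(NCc3ccc(-c4ccccn4)cc3)nc(SCC(C)(C)O)nc12` gives 507 nM. Compound 4 `CC(C)c1n[nH]c2c(NCc3ccc(-c4ccccn4)cc3)nc(SC3CCCC3O)nc12` has not yet been measured; it differs from compound 1 by 2-hydroxycyclopentyl in place of carbamoylmethyl on a sulfur. For the measured compounds named here, two measured steps bear on this change. One, a 2.4-fold lower number from compound 1 to compound 2 (0.38 log units; beyond the scatter), came with a 2-oxo-1,3-oxazolidin-5-yl in place of carbamoyl on a saturated chain carbon bound to a sulfur. The other, a 2.6-fold higher number from compound 1 to compound 3 (0.42 log units; beyond the scatter), came with a 1-hydroxy-1-methylethyl in place of carbamoyl at the same place, and the two replacements stand apart by a 6.3-fold higher number from compound 2 to compound 3 (0.80 log units; beyond the scatter). The group entering compound 4 brings a ring, as in compound 2, but carries a hydroxyl and no carbonyl, as in compound 3. Because a 2.6-fold higher number from compound 1 to compound 3 (0.42 log units; beyond the scatter) shows the hydroxyl-bearing change raised the number, a modest rise is expected, a 2.1-fold higher number from compound 1 to compound 4 (0.32 log units; beyond the scatter). Compound 4 is therefore estimated at 400 nM, with a range from 150 nM to 1100 nM.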

Compound 4, concentration for 50% growth inhibition: 567 nM
Compound 4: the middle estimate sits 1.4-fold (0.15 log units) below what was measured; measured number inside the range.
By their numbers in this assay, from the lowest: compound 2; then compound 1; then compounds 3 and 4 (each within the scatter of the next).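

In this assay, 2-hydroxycyclopentyl in place of carbamoylmethyl on the sulfur gives a 3.0-fold higher number from compound 1 to compound 4 (0.47 log units; beyond the scatter) and so joins the hydroxyl-bearing group of compound 3 on the weaker side of compound 1. The ring makes no measurable difference between these two hydroxyl-bearing groups, with a 1.1-fold higher number from compound 3 to compound 4 (0.05 log units; within the scatter), and a ring on its own does not reproduce the result of compound 2, as a 7.1-fold higher number from compound 2 to compound 4 (0.85 log units; beyond the scatter) shows; among these compounds, only the ring with the carbonyl, 2-oxo-1,3-oxazolidin-5-yl, gives a number lower than that of compound 1. No available measurement explains these differences.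

A plain cyclopentyl or a 2-aminocyclopentyl on the sulfur would test whether the hydroxyl matters at all. From the compounds shown here alone, whether a carboxylic acid or a longer chain there would go below compound 2 remains open.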